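Swapping a chloro for a methyl on a shared core

The source may hold more compounds than are shown below. What is called first, only, known or untested is meant among the compounds shown, and "the series" means these compounds.

Three compounds sharing a small heterocyclic core were examined in an ADME assay on L02 cells (Homo sapiens) for inhibition, read by MTT assay, with a stated time of 48 h, tested at 100 uM; a higher number here means more inhibition at the concentration tested (going by the name of the read-out), a lower number less inhibition. Compound 1 `O=c1oc(-c2ccc([N+](=O)[O-])cc2Cl)ns1` gives 54.6%. Compound 2 `O=c1nc(-c2cccnc2Cl)ss1` gives 34.4%. Compound 3 `O=c1oc(-c2ccccc2Cl)ns1` gives 20.6%, the lowest of the three numbers; its nearest neighbour, compound 2, lies beyond the scatter above it, and compound 1 lies furthest above it.

Going by the values given here, only one step between measured compounds differs in a single place: a number 34 percentage points lower from compound 1 to compound 3 (beyond the scatter). Removing the nitro therefore cut inhibition sharply.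

Compound 4 `Cc1ccccc1-c1nsc(=O)o1` differs from compound 3 by methyl in place of chloro on an aromatic carbon. Among the compounds with values here, no measured step involves this exchange, so the one available step speaks only to the nitro and says nothing about the chloro. Both groups leaving and entering are single heavy atoms, carry no donors or acceptors and no charge. Within the data shown here, with no direct precedent, the expected change in this assay is none beyond the scatter, with the number staying near the low end already seen for compound 3.

The estimated value for compound 4 is 17%, within a range of 2% to 34%, which means an expected step of a number 3.6 percentage points lower from compound 3 to compound 4 (within the scatter).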

Compound 4, a percentage reported as inhibition, at one concentration (the size of the read-out at that concentration, not a potency): 18.1%
Estimate against measurement, compound 4: 1.1 percentage points below; measured number inside the range.
By their numbers in this assay, from the lowest: compounds 4 and 3 (each within the scatter of the next); then compound 2; then compound 1.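

In this assay, putting methyl in place of chloro on an aromatic carbon, ortho to a group of 6 heavy atoms, gives a number 2.5 percentage points lower from compound 3 to compound 4 (within the scatter), so this exchange leaves the read-out where it was. Going by these compounds alone, the only earlier step between compounds differing in one place, a number 34 percentage points lower from compound 1 to compound 3 (beyond the scatter), concerned the nitro and was beyond the scatter, whereas this one shows that at this other position the read-out does not depend on having chloro rather than methyl, at least on the shared core of compound 3. Nothing available explains why the two groups give matching numbers, and no measurement of any property of these compounds bears on the result.

On these data alone, this is one exchange at one position, so it remains open whether a group of a different kind there, such as an amine, a carboxylic acid or a longer chain, would move the number beyond the scatter. As far as these compounds go, it also remains open whether the same exchange would be as quiet on the nitro-bearing compound 1, which sits much higher in this assay.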